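Trimethoxyphenyl for fluorophenyl on a bis-arylidene piperidinone

The compounds below may be only part of what the source reports. "The series", "measured", "known", "first", "only" and "open" are said of these compounds alone.

Measured compounds:
compound 1 `O=C1/C(=C/c2ccccc2F)CN(S(=O)(=O)c2ccc(F)cc2)C/C1=C\c1ccccc1F` gives 8500 nM
compound 2 `N#Cc1ccc(/C=C2\CN(S(=O)(=O)c3ccc(F)cc3)C/C(=C\c3ccccc3F)C2=O)cc1` gives 20100 nM
compound 3 `COc1cc(/C=C2\CN(S(=O)(=O)c3ccc(F)cc3)C/C(=C\c3ccccc3F)C2=O)cc(OC)c1` gives 14000 nM

These values come from a functional assay on QGY-7703 cells (Homo sapiens) for cytotoxicity, read by MTT assay, with a stated time of 24 h; on this read-out higher numbers stand for weaker inhibition and lower numbers for stronger inhibition. Compound 2 gives the highest number of the three: compound 3 sits nearest, and the gap between them is within the scatter, so no order can be read between compound 2 and compound 3; compound 1 lies furthest from compound 2, and the step of a 2.4-fold higher number from compound 1 to compound 2 (0.37 log units; beyond the scatter) is modest but beyond the scatter.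

The unmeasured compound 4 `COc1cc(/C=C2\CN(S(=O)(=O)c3ccc(F)cc3)C/C(=C\c3ccc(C#N)cc3)C2=O)cc(OC)c1OC` differs from compound 2 by a single change: 3,4,5-trimethoxyphenyl in place of 2-fluorophenyl on a double-bonded chain carbon bound to a double-bonded ring carbon.

The closest measured precedent is the step of a 1.6-fold higher number from compound 1 to compound 3 (0.22 log units; within the scatter), where a methoxy-bearing phenyl also replaced 2-fluorophenyl at the same place, and that step stayed within the scatter. The step of a 1.4-fold lower number from compound 2 to compound 3 (0.16 log units; within the scatter) also stayed within the scatter. With both neighbouring steps small, no movement beyond the scatter is expected in this assay for compound 4, with a slight drift toward a higher number if anything.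

Compound 4 is therefore expected to give about 25000 nM, in a range from 10000 nM to 60000 nM; this estimate implies a step of a 1.2-fold higher number from compound 2 to compound 4 (0.09 log units; within the scatter).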

Compound 4, half-maximal inhibitory concentration: 4980 nM
The estimate for compound 4 lay 5.0-fold (0.70 log units) above the measured number, and the stated range ends above it.
By their numbers in this assay, from the lowest: compounds 4, 1, 3 and 2 (each within the scatter of the next, the first and the last beyond it).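

In this assay, the place on a double-bonded chain carbon bound to a double-bonded ring carbon proved able to move the number downward: with 3,4,5-trimethoxyphenyl in place of 2-fluorophenyl, the result was a 4.0-fold lower number from compound 2 to compound 4 (0.61 log units; beyond the scatter). The earlier steps at this place had either raised the number beyond the scatter or stayed within it, so this is the first step shown that lowers it beyond the scatter. No measurement shown here accounts for the drop.

The compounds shown leave open whether 3,4,5-trimethoxyphenyl would lower the number similarly with 2-fluorophenyl rather than 4-cyanophenyl on the other double-bonded chain carbon. They also leave open how a 4-hydroxyphenyl or a pyridine ring would behave at this place.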